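Chloro on the phenyl ring: a step without precedent

The source may report more compounds than this note shows. Statements on the series, on what has been measured and on what is new or still open speak of the compounds shown alone.

Compound 1 `COc1cc(/C=C/C(=O)c2cccc(-n3cc(-c4ccccc4)[nH]c3=O)c2)ccc1O` — 3310 nM
Compound 2 `COc1cc(/C=C/C(=O)c2cccc(-n3cc(-c4ccccc4)[nH]c3=O)c2)cc(OC)c1OC` — 2090 nM

In a functional assay on SN12C cells (Homo sapiens) for inhibition (on this read-out lower numbers stand for stronger inhibition of growth and higher numbers for weaker inhibition of growth), compound 1 gives 3310 nM. Where compound 1 carries one methoxy and one hydroxyl, three methoxy groups sit in compound 2, which gives 2090 nM. The two numbers lie within the usual scatter of each other, so neither compound can be set above the other on these measurements.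

Compound 3 `COc1cc(/C=C/C(=O)c2cccc(-n3cc(-c4ccc(Cl)cc4)[nH]c3=O)c2)ccc1O` follows from compound 1 by one change: chloro in place of hydrogen on an aromatic carbon. The change is chloro in place of hydrogen on an aromatic carbon, para to a large group; read one bond further out, phenyl becomes 4-chlorophenyl. Among the measured compounds shown here, no measured pair shows what such a change does in this assay, so there is nothing to carry over beyond the value of compound 1 itself.

Compound 3 is therefore expected to stay close to compound 1, with the step of a 1.3-fold lower number from compound 1 to compound 3 (0.10 log units; within the scatter) lying within the scatter, in no clear direction. The estimate for compound 3 is 2600 nM, with a range from 900 nM to 7500 nM.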

Compound 3, concentration for 50% growth inhibition: 2870 nM
Compound 3: middle estimate off by 1.1-fold (0.04 log units), on the low side; measured number inside the range.
By their numbers in this assay, from the lowest: compounds 2, 3 and 1 (each within the scatter of the next).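

The step from phenyl to 4-chlorophenyl, with chloro in place of hydrogen on an aromatic carbon para to a large group, reads a 1.2-fold lower number from compound 1 to compound 3 (0.06 log units; within the scatter) in this assay. This gives the series its first measured look at this place on the ring: adding a chloro here leaves the two compounds indistinguishable on this read-out, so the place can carry this one atom with no measurable gain or loss in growth inhibition. Nothing measured here offers an explanation for how close the two numbers lie.

Going by these compounds, whether a different group at the same place, such as an amine, a carboxylic acid or a longer chain, would move the number beyond the scatter remains open. So does whether the same chloro step would read alike on compound 2, with its three methoxy groups.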